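Piperazinone series: aryl thiophene replacing chloro

This account rests on a few compounds, and the source may have more. Where it says the series, first, only, none or still open, it means among the compounds named here.

Measured so far in a functional assay on cells for inhibition of Polyunsaturated fatty acid 5-lipoxygenase (Homo sapiens); on this read-out higher numbers stand for weaker inhibition and lower numbers for stronger inhibition:
compound 1 `O=C1NCCN(c2cccc(Cl)c2)N1`, 2100 nM
compound 2 `CCC1CN(c2ccccc2)NC(=O)N1`, 3800 nM
compound 3 `CC1CN(c2cccc(Cl)c2)NC(=O)N1`, 2700 nM

Compound 1 sits at the low end of the three numbers, but the three values lie close together. Among the measured compounds shown here, the only single-point step is a 1.3-fold higher number from compound 1 to compound 3 (0.11 log units; within the scatter), which concerns a saturated ring carbon and is within the scatter. For the measured compounds named here, two places at once separate compound 1 from compound 2, so the value of compound 2, 3800 nM, gives no isolated step.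

Compound 4 `O=C1NCCN(c2cccc(-c3ccsc3)c2)N1` is unmeasured. It differs from compound 1 as follows: thiophen-3-yl in place of chloro on an aromatic carbon. Going by the values given here, no measured step touches the aromatic ring, so nothing in this set speaks to the size or direction of the change, and the expectation must rest on compound 1 alone with a wide range. The working estimate for compound 4 is 1500 nM, bounded by 300 nM and 7000 nM. This estimate corresponds to a 1.4-fold lower number from compound 1 to compound 4 (0.15 log units; within the scatter), a step expected to fall within the scatter.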

Compound 4, half-maximal inhibitory concentration: 5300 nM
Estimate against measurement, compound 4: 3.5-fold (0.55 log units) below; the range from low to high includes it.
By their numbers in this assay, from the lowest: compounds 1, 3, 2 and 4 (each within the scatter of the next, the first and the last beyond it).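

Among the compounds shown here, on this aromatic carbon, thiophen-3-yl in place of chloro weakens inhibition in this assay, with a 2.5-fold higher number from compound 1 to compound 4 (0.40 log units; beyond the scatter), the first step in this set that lies beyond the scatter. The position therefore responds to the group it carries, yet the step is modest: the aromatic carbon keeps measurable inhibition with a five-membered aromatic ring in place of the single chlorine. Nothing available bears on why this step occurs.

On these data alone, whether the loss is particular to thiophen-3-yl or extends to other groups on this carbon remains open; a phenyl, a methoxy or an amine there would help to separate these cases. Also open, as far as these compounds go, is whether thiophen-3-yl produces a similar step on the methyl-bearing core of compound 3.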